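Compound 3 and the step to a dichlorinated benzyl group

The compounds below may be only part of what the source reports. "The series", "measured", "known", "first", "only" and "open" are said of these compounds alone.

Measured in a functional assay on the whole organism with Rattus norvegicus as the target; a higher number here means that more compound is needed for the effect, a lower number that less compound is needed:
- compound 1 `COc1cc(N)c(Cl)cc1C(=O)NCCN(C)C(C)c1ccccc1`: 1 mg/kg
- compound 2 `COc1cc(N)c(Cl)cc1C(=O)NCCN(C)CC1CCCCC1`: 3 mg/kg
- compound 3 `CCN(CCNC(=O)c1cc(Cl)c(N)cc1OC)Cc1cccc(OC)c1`: 1 mg/kg

Compound 3 gives 1 mg/kg. This is level with compound 1 at the digits shown, and the two share the lowest of the three numbers, while compound 2 stands furthest from them at 3 mg/kg.

The next compound is compound 4 `CCN(CCNC(=O)c1cc(Cl)c(N)cc1OC)Cc1ccc(Cl)cc1Cl`, which carries 2,4-dichlorophenyl in place of 3-methoxyphenyl on a saturated chain carbon bound to an amine nitrogen. The group that leaves and the group that enters have the same number of heavy atoms, but the entering one has no hydrogen-bond acceptor.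

For the measured compounds named here, only one measured step offers a guide: a 3.0-fold higher number from compound 1 to compound 2 (0.48 log units; beyond the scatter), with cyclohexylmethyl in place of 1-phenylethyl on an amine nitrogen. That step is modest and involves different groups, so it gives a rough size but no reliable direction. Going by the values given here, no measured compound carries 2,4-dichlorophenyl. A change no larger than that modest step is therefore expected, probably not beyond the scatter. The estimated step is a 1.5-fold higher number from compound 3 to compound 4 (0.18 log units; within the scatter). For compound 4 the estimated value in this assay is 1.5 mg/kg, with an expected range from 0.5 mg/kg to 5 mg/kg.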

Compound 4, dose for half-maximal effect: 10 mg/kg
Estimate against measurement, compound 4: 6.7-fold (0.82 log units) below; measured number outside the range, above it.
By their numbers in this assay, from the lowest: compounds 1 and 3 (each within the scatter of the next); then compound 2; then compound 4.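

In this assay, the place on a saturated chain carbon bound to an amine nitrogen proves sensitive to the aromatic group it carries: 2,4-dichlorophenyl in place of 3-methoxyphenyl gives a 10-fold higher number from compound 3 to compound 4 (1.00 log units; beyond the scatter), and compound 4 now has the highest number of the four compounds. The earlier compounds shown here offered only a 3.0-fold higher number from compound 1 to compound 2 (0.48 log units; beyond the scatter), a change of a different kind, whereas here a step beyond the scatter appears even though both groups have the same heavy-atom count and the same single six-membered aromatic ring of carbon only, and differ in what that ring carries, with the entering group lacking the hydrogen-bond acceptor of the leaving one. Nothing shown here gives a measured reason for the size of this step.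

Still open, on these data alone, is whether the step follows the loss of the methoxy group or the arrival of the chlorines, a question that plain phenyl or a monochlorophenyl on the same carbon would help to separate. Also open, as far as these compounds go, is whether the step would hold with methyl in place of ethyl on the amine nitrogen.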